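This account rests on a few compounds, and the source may have more. Where it says the series, first, only, none or still open, it means among the compounds named here.

Compound 1 `COc1ccc(CNc2cc(Oc3ccc(NC(=O)Nc4ccc(C)c(C(F)(F)F)c4)cc3)ncn2)cc1` gives the lower of the two measured numbers in a functional assay on BaF3 cells (Mus musculus) for inhibition, read by CCK-8 assay, with a stated time of 72 h (a higher number here means a weaker inhibitor of growth, a lower number a stronger inhibitor of growth), where compound 1 gives 1000 nM. Compound 2 `Cc1ccc(NC(=O)Nc2ccc(Oc3cc(N4CCN[C@H](C)C4)ncn3)cc2)cc1C(F)(F)F` shares the core, and in this assay compound 2 gives 8920 nM. That step is an 8.9-fold higher number from compound 1 to compound 2 (0.95 log units; beyond the scatter), with 3-methylpiperazin-1-yl in place of (4-methoxybenzyl)amino on an aromatic carbon. Compound 3 `Cc1ccc(NC(=O)Nc2ccc(Oc3cc(NCCO)ncn3)cc2)cc1C(F)(F)F` has not yet been measured; it differs from compound 1 by hydroxymethyl in place of 4-methoxyphenyl on a saturated chain carbon bound to a nitrogen on an aromatic ring, so (4-methoxybenzyl)amino becomes (2-hydroxyethyl)amino. Among the compounds with values here, the only measured step that bears on this is the one from compound 1 to compound 2, where a (4-methoxybenzyl)amino group likewise left and the number rose beyond the scatter. A rise of the same kind, though not necessarily as large, is expected here, and the expected step is a 4.0-fold higher number from compound 1 to compound 3 (0.60 log units; beyond the scatter). Compound 3 is therefore estimated at about 4000 nM in this assay, within a range from 1500 nM to 12000 nM.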

Compound 3, concentration for 50% growth inhibition: > 10000 nM
Compound 3: a limit, no number (the forecaster's own chance of this, stated with the estimate: 5%); middle value at least 2.5-fold (0.39 log units) away from the limit.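

Compound 3 stands at a limit and not a number: the limit of > 10000 nM in this assay, at which 1 of the 3 values shown sits. Hydroxymethyl in place of 4-methoxyphenyl on a saturated chain carbon bound to a nitrogen on an aromatic ring gives an at least 10-fold higher number from compound 1 to compound 3 (1.00 log units; beyond the scatter), so a rise beyond the scatter is not confined to the entry of 3-methylpiperazin-1-yl and also occurs with an open-chain replacement that carries no ring. Within the data shown here, the two replacements of (4-methoxybenzyl)amino cannot be ranked against each other, as the only reading is an at least 1.1-fold higher number from compound 2 to compound 3 (0.04 log units; that floor lies within the scatter).

The compounds shown leave open whether the step follows from the loss of the aromatic ring or of its methoxy group. A plain benzylamino group or a (2-methoxyethyl)amino chain on the shared core would bear on that question.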